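Shifting the Methoxy Substituent from Compound 3 to Compound 4

A few compounds are considered here, and "the series" means these few. Any claim that something is new, unique, unknown or untested is made for them only; others in the source may bear on it.

Three esters have been tested in a functional assay on the whole organism (strain Kunming) with Mus musculus as the target, with a stated time of 0.5 h, at a dose of 300 mg/kg by the intraperitoneal route; on this read-out lower numbers stand for a stronger effect and higher numbers for a weaker effect at the one dose given. Compound 1 `COc1ccccc1/C=C/C(=O)OC/C=C/c1cc(OC)c(OC)cc1OC` gives 100% in this assay. Compound 2 `COc1cc(OC)c(OC)cc1/C=C/COC(=O)/C=C/c1ccc(F)cc1` gives 75%, and compound 3 `COc1cccc(/C=C/C(=O)OC/C=C/c2cc(OC)c(OC)cc2OC)c1` gives 75%. Among these three numbers compound 3 stands level with compound 2 at the digits printed, the two together being the lowest of the set, while compound 1 sits apart: the step of a number 25 percentage points lower from compound 1 to compound 3 (beyond the scatter) lies beyond the scatter, and the step of no change at the digits printed from compound 2 to compound 3 (within the scatter) lies within it.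

Compound 4 `COc1ccc(/C=C/C(=O)OC/C=C/c2cc(OC)c(OC)cc2OC)cc1` has not yet been measured. It differs from compound 3 in one place: 4-methoxyphenyl in place of 3-methoxyphenyl on a double-bonded chain carbon bound to a double-bonded chain carbon.

Within the data shown here, two measured steps bear on this change. The step of a number 25 percentage points lower from compound 1 to compound 2 (beyond the scatter) and the step of a number 25 percentage points lower from compound 1 to compound 3 (beyond the scatter) show that replacing 2-methoxyphenyl lowers the number by a modest amount in either direction tried, whereas the step of no change at the digits printed from compound 2 to compound 3 (within the scatter) shows that 4-fluorophenyl and 3-methoxyphenyl give the same number. Among the measured compounds shown here, a 4-methoxyphenyl group has no direct precedent here, so the expectation rests on compound 2 and compound 3 both giving the same read-out. The step of no change at the digits printed from compound 3 to compound 4 (within the scatter) is therefore expected to stay within the scatter. Compound 4 is estimated to give 75% in this assay, with a range from 55% to 100%.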

Compound 4, a percentage reported as activity, at one dose (the size of the read-out at that dose, not a potency): 100%
Compound 4: middle estimate off by 25 percentage points, on the low side, and the stated range covers the measured number.
By their numbers in this assay, from the lowest: compounds 2 and 3 (each within the scatter of the next); then compounds 1 and 4 (each within the scatter of the next).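

In this assay, the step of a number 25 percentage points higher from compound 3 to compound 4 (beyond the scatter) shows that the place of the methoxy on the phenyl group matters by itself: 3-methoxyphenyl and 4-methoxyphenyl have the same atoms, joined differently, yet they do not give the same read-out. The step of a number 25 percentage points higher from compound 2 to compound 4 (beyond the scatter), methoxy in place of fluoro on an aromatic carbon, shows that the match between the 4-fluorophenyl group and the 3-methoxyphenyl group does not extend to 4-methoxyphenyl, while the step of no change at the digits printed from compound 1 to compound 4 (within the scatter) places 4-methoxyphenyl level with 2-methoxyphenyl, so that among the three methoxy isomers only the 3-methoxyphenyl group of compound 3 stands apart. No measurement at hand accounts for this difference between the isomers.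

The compounds shown leave open whether the lower number belongs to the 3-methoxyphenyl group alone or would also come with a 3-ethoxyphenyl or 3-aminophenyl group on the same double-bonded chain carbon. They also leave open whether these steps would hold at other doses, each number being the size of the read-out at one dose and not a potency.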